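Chloro removal on the pendant phenyl of the quinoline carboxamide series

A few compounds are considered here, and "the series" means these few. Any claim that something is new, unique, unknown or untested is made for them only; others in the source may bear on it.

Compound 2 `COc1cc2c(Oc3ccc(NC(=O)c4cc(-c5ccc(Cl)c(Cl)c5)nc5ccccc45)cc3F)ccnc2cc1OCCCN1CCCCC1` gives 820 nM in a functional assay on NCI-H460 cells (Homo sapiens) for cytotoxicity, read by MTT assay, with a stated time of 72 h; on this read-out higher numbers stand for weaker inhibition and lower numbers for stronger inhibition. Compound 1 `COc1cc2c(Oc3ccc(NC(=O)c4cc(-c5cccc(Cl)c5)nc5ccccc45)cc3F)ccnc2cc1OCCCN1CCCCC1` gives 11 nM in this assay, and the step of a 75-fold lower number from compound 2 to compound 1 (1.87 log units; beyond the scatter) follows from the change (hydrogen in place of chloro on an aromatic carbon). Compound 3 `COc1cc2c(Oc3ccc(NC(=O)c4cc(-c5cccc(Cl)c5)nc5ccccc45)cc3F)ccnc2cc1OCCCN1CCC(C)CC1` gives 65 nM; the step of a 5.9-fold higher number from compound 1 to compound 3 (0.77 log units; beyond the scatter) arises from methyl in place of hydrogen on a saturated ring carbon. The difference between the cores of compound 3 and compound 2 is not broken down here. Compound 4 `COc1cc2c(Oc3ccc(NC(=O)c4cc(-c5ccccc5)nc5ccccc45)cc3F)ccnc2cc1OCCCN1CCC(C)CC1` is not yet measured; it differs from compound 3 by hydrogen in place of chloro on an aromatic carbon, the same kind of change as that from compound 2 to compound 1, but the earlier site was ortho to a chloro group and para to a large group, whereas this one is meta to a large group. Within the data shown here, because the single precedent a 75-fold lower number from compound 2 to compound 1 (1.87 log units; beyond the scatter) sits at a differently surrounded position, only a small step of a 2.3-fold higher number from compound 3 to compound 4 (0.36 log units; beyond the scatter) is expected. Compound 4 is estimated at 150 nM, between 40 nM and 600 nM.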

Compound 4, half-maximal inhibitory concentration: 68 nM
Estimate against measurement, compound 4: 2.2-fold (0.34 log units) above; measured number inside the range.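

In this assay, going from 3-chlorophenyl to phenyl on the methyl-bearing core leaves the number in place (a 1.0-fold higher number from compound 3 to compound 4 (0.02 log units; within the scatter)). Hydrogen in place of chloro on an aromatic carbon therefore does not carry over from one core to the other with one step size: the same change on two cores in this assay, a 75-fold lower number (1.87 log units; beyond the scatter) from compound 2 to compound 1 and a 1.0-fold higher number (0.02 log units; within the scatter) from compound 3 to compound 4, 78-fold (1.89 log units) apart, beyond the scatter of two such steps. The two pairs differ both in the methyl on the saturated ring and in the surroundings of the chloro that leaves, so these steps do not show which of the two accounts for the gap.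

Open, from the compounds shown here alone, is how 3-chlorophenyl to phenyl behaves on the core of compound 1, without the methyl. Also open, going by these compounds, is whether a fluoro, methoxy or nitrile at the chloro site, or a morpholine in place of the saturated ring, would fit these steps.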